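Pyridyl isomer swap on the guanylhydrazone series

The source may hold more compounds than are shown below. What is called first, only, known or untested is meant among the compounds shown, and "the series" means these compounds.

Measured so far:
compound 1 `Cc1cn2c(/C=N/NC(=N)N)c(-c3ccncc3)nc2s1` — 30900 nM
compound 2 `Cc1sc2nc(-c3ccncc3)c(/C=N/NC(=N)N)n2c1C` — 93300 nM

Two compounds have been run in a functional assay on CNS cells (Homo sapiens) for antiproliferative activity; on this read-out higher numbers stand for weaker inhibition of growth and lower numbers for stronger inhibition of growth. Compound 1 holds the lower of the two numbers, and in this assay compound 1 gives 30900 nM. Among the compounds with values here, compound 2 differs from it by a methyl in place of hydrogen on an aromatic carbon, and in this assay compound 2 gives 93300 nM; the single step of a 3.0-fold higher number from compound 1 to compound 2 (0.48 log units; beyond the scatter) is modest but beyond the scatter.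

Compound 3 `Cc1cn2c(/C=N/NC(=N)N)c(-c3cccnc3)nc2s1` is not yet measured. It differs from compound 1 by pyridin-3-yl in place of pyridin-4-yl on an aromatic carbon. Within the data shown here, the one measured step concerns a methyl added elsewhere on the shared core and does not bear on a change of the pyridyl attachment point, so there is no measured precedent for this move. With nothing to anchor a direction, no step beyond the scatter is expected, and the estimate for compound 3 is 32000 nM with a range of 11000 nM to 95000 nM, corresponding to an expected step of a 1.0-fold higher number from compound 1 to compound 3 (0.02 log units; within the scatter).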

Compound 3, concentration for total growth inhibition: 28200 nM
Beside the measured number, compound 3's estimate is 1.1-fold (0.05 log units) above it; low and high end bracket the measured number.
By their numbers in this assay, from the lowest: compounds 3 and 1 (each within the scatter of the next); then compound 2.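

In this assay, within the data shown here, this is the first read on the aryl position, as the earlier step concerned a methyl elsewhere on the shared core: a 1.1-fold lower number from compound 1 to compound 3 (0.04 log units; within the scatter) is the whole effect of exchanging pyridin-4-yl for pyridin-3-yl on this aromatic carbon. The two isomers therefore cannot be told apart on this read-out, so within this pair the location of the nitrogen in the six-membered aromatic ring makes no difference that can be read, while the methyl step a 3.0-fold higher number from compound 1 to compound 2 (0.48 log units; beyond the scatter) remains the only one shown beyond the scatter. No supporting data bear on why the isomers read alike, and the result is recorded here as an observation only.

The compounds shown do not tell whether the position would respond to a larger departure, such as pyridin-2-yl, a plain phenyl ring, or a phenyl ring carrying an amine or a carboxylic acid. They also leave open whether pyridin-3-yl would read the same on the core of compound 2, which carries the added methyl.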